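From oxetan-3-yl to 3,3,3-trifluoropropyl on a shared core

The source may hold more compounds than are shown below. What is called first, only, known or untested is meant among the compounds shown, and "the series" means these compounds.

- Compound 1 `CC[C@@H]1C(=O)N(C)c2cnc(-n3ccnc3-c3ccc(F)cc3)nc2N1[C@H]1CCOC1`: 58%
- Compound 2 `CC[C@@H]1C(=O)N(C)c2cnc(-n3ccnc3-c3ccc(F)cc3)nc2N1C1COC1`: 74%

In an ADME assay on microsomes from liver (Homo sapiens) for metabolic stability, with a stated time of 30 min, tested at 1 uM (on this read-out lower numbers stand for a less stable compound and higher numbers for a more stable compound), compound 2 is the higher of the two, at 74%. Compound 3 `CC[C@@H]1C(=O)N(C)c2cnc(-n3ccnc3-c3ccc(F)cc3)nc2N1CCC(F)(F)F` differs from it as follows: 3,3,3-trifluoropropyl in place of oxetan-3-yl on a nitrogen on an aromatic ring in a ring. Among the measured compounds shown here, one measured step bears on this place: a number 16 percentage points higher from compound 1 to compound 2 (beyond the scatter), which exchanges one ring for another. For the measured compounds named here, no measured compound has an open chain here, so this is only a loose guide. A modest fall is expected, and the expected step in this assay is a number 12 percentage points lower from compound 2 to compound 3 (beyond the scatter). Compound 3 is estimated at 62%, with an expected range of 42% to 80%.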

Compound 3, percent of the compound remaining in the Homo sapiens assay: 27%
Beside the measured number, compound 3's estimate is 35 percentage points above it; the measured number lies below the stated range.
By their numbers in the Homo sapiens assay, from the lowest: compound 3; then compound 1; then compound 2.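

In the Homo sapiens assay, the 3,3,3-trifluoropropyl chain brings a far larger fall than the ring-for-ring exchange suggested: a number 47 percentage points lower from compound 2 to compound 3 (beyond the scatter), and a number 31 percentage points lower from compound 1 to compound 3 (beyond the scatter). The group on this nitrogen can therefore move stability much further than the two rings alone showed, and both ring-bearing compounds stand above the open chain. In a physicochemical assay for lipophilicity (on this read-out lower numbers stand for lower lipophilicity and higher numbers for higher lipophilicity), compound 2 gives 1.6 and compound 3 gives 3.1. The fall comes with a rise in lipophilicity, which may be part of its cause: the measured partition coefficient of compound 2, 1.6, and of compound 3, 3.1, a number 1.50 log units higher (beyond the scatter)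

Going by these compounds, whether the fall follows the loss of the ring or the entry of the fluorine atoms stays open. A plain propyl chain or a methoxyethyl group on this nitrogen would separate the two.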